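Methyl on a Fused Core: Three Limits and One Open Question

This account rests on a few compounds, and the source may have more. Where it says the series, first, only, none or still open, it means among the compounds named here.

Compound 1, `Sc1nncc2cncn12`, in a functional assay for inhibition, with Homo sapiens as the target (a lower number here means a stronger inhibitor, a higher number a weaker inhibitor), gives > 48000 nM, a limit of the assay rather than a number.
Compound 2, `Cc1ncn2c(S)nncc12`, in this assay gives > 48000 nM, again a limit.
Compound 3, `C=CCn1ncc2cncn2c1=O`, in this assay gives > 48000 nM, also a limit.

Compound 2 differs from compound 1 by methyl in place of hydrogen on an aromatic carbon. The step that the two limits leave unreadable from compound 1 to compound 2 cannot be read, since both ends sit at a limit; this is summed up by the limit of > 48000 nM in this assay, at which 3 of the 3 values shown sit. Compound 3 has a different core, and the difference between the two cores is not broken down here.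

Compound 4, `C=CCn1ncc2cnc(C)n2c1=O`, has not yet been measured. It differs from compound 3 by methyl in place of hydrogen on an aromatic carbon. For the measured compounds named here, this is the same kind of change as the one from compound 1 to compound 2, though what surrounds the place differs: in compound 2 the methyl sits next to the ring nitrogen, two ring bonds from the ring nitrogen, whereas in compound 4 it sits between two ring nitrogen atoms.

Going by the values given here, for compound 4 in this assay the expected step is a step that the limit leaves unreadable from compound 3 to compound 4, resting on (the limit of > 48000 nM in this assay, at which 3 of the 3 values shown sit), where every value so far is a limit. Compound 4 is therefore expected to give about 60000 nM, most likely reported again as a limit, with a plausible range from 20000 nM to 200000 nM.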

Compound 4, half-maximal inhibitory concentration: > 48000 nM
Compound 4: a limit, no number; the forecaster's own chance of this, stated with the estimate: 85%; the middle value is on the limit's open side.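

In this assay compound 4 gives > 48000 nM, which is a limit of the assay and not a number. Compound 3 also sits at a limit, so the step between compound 3 and compound 4 cannot be read: the limit of > 48000 nM in this assay, at which 4 of the 4 values shown sit. The compounds shown leave open how strong an inhibitor any of the four is, and whether methyl in place of hydrogen on an aromatic carbon changes that strength at all.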